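The compounds below may be only part of what the source reports. "The series", "measured", "known", "first", "only" and "open" are said of these compounds alone.

Measured compounds:
Compound 1, `CCCC[C@H](C)C[C@H](O)/C=C/[C@H]1[C@H](O)CC(=O)[C@@H]1SCCCCCC(=O)O`: 6.1 nM
Compound 2, `COCc1cccc(C[C@H](O)/C=C/[C@H]2[C@H](O)CC(=O)[C@@H]2SCCCSCC(=O)O)c1`: 1200 nM

Both compounds share a core and were tested in an assay on CHO cells for displacement of a labelled ligand from prostaglandin E2 receptor EP3 subtype (Mus musculus); on this read-out higher numbers stand for weaker inhibition and lower numbers for stronger inhibition. Compound 1 gives 6.1 nM in this assay, whereas compound 2 gives 1200 nM, the higher of the two numbers, and the gap between them is far beyond the scatter of repeated measurements. The two differ in more than one place, so nothing more than this comparison of the two values can be said about them.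

Compound 3, `CCOCc1cccc(C[C@H](O)/C=C/[C@H]2[C@H](O)CC(=O)[C@@H]2SCCCSCC(=O)O)c1`, has not been measured. It differs from compound 2 by a single small change: methyl in place of hydrogen on a saturated chain carbon bound to an oxygen on a saturated carbon. Within the data shown here, no pair of measured compounds shows the effect of such a change here. The step is expected to be small, in either direction or none beyond the scatter, so the step from compound 2 to compound 3 in this assay is estimated at a 1.2-fold lower number from compound 2 to compound 3 (0.08 log units; within the scatter). For compound 3 the estimate in this assay is 1000 nM, in a range from 400 nM to 3000 nM.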

Compound 3, inhibition constant: 4500 nM
For compound 3 the middle estimate is 4.5-fold (0.65 log units) below the measured one; the measured number lies above the stated range.
By their numbers in this assay, from the lowest: compound 1; then compound 2; then compound 3.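

In this assay the change from methoxymethyl to ethoxymethyl gives a 3.8-fold higher number from compound 2 to compound 3 (0.57 log units; beyond the scatter) and is the only single change among these compounds whose effect can be read on its own. It shows that this position responds even to one added methyl on a saturated chain carbon bound to an oxygen on a saturated carbon: the step is modest, but it lies beyond the scatter and goes towards weaker inhibition, which the comparison of compound 1 with compound 2 could not reveal for this group. Nothing in the data at hand explains why this small addition has this effect.

Going by these compounds, a single step gives a direction for this one change, not a trend, so it remains open whether a longer chain such as propoxymethyl would continue the move towards weaker inhibition, or whether a hydroxymethyl or aminomethyl group would reverse it. The compounds shown also leave open how much of the large gap between compound 1 and compound 2 comes from the methoxymethyl-bearing end of the molecule and how much from the other places in which they differ.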